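From Isopropyl to Butyl: A Step Still Unmeasured

The compounds below may be only part of what the source reports. "The series", "measured", "known", "first", "only" and "open" are said of these compounds alone.

In a functional assay on the whole organism with Scenedesmus acutus as the target, with a stated time of 20 h (on this read-out higher numbers stand for weaker inhibition and lower numbers for stronger inhibition), compound 1 (`O=C(O)c1cc(N2C(=O)C3=C(CCCC3)C2=O)ccc1Cl`) gives > 100000 nM, which is a limit of the assay and not a number.

Compound 2 (`CCOC(=O)c1cc(N2C(=O)C3=C(CCCC3)C2=O)ccc1Cl`) gives 2140 nM, and compound 3 (`CC(C)OC(=O)c1cc(N2C(=O)C3=C(CCCC3)C2=O)ccc1Cl`) gives 182 nM, the lowest number of the three. All three measured steps on this oxygen were large and beyond the scatter: an at least 46-fold lower number from compound 1 to compound 2 (1.66 log units; beyond the scatter), an at least 540-fold lower number from compound 1 to compound 3 (2.73 log units; beyond the scatter) and a 12-fold lower number from compound 2 to compound 3 (1.07 log units; beyond the scatter).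

Compound 4 (`CCCCOC(=O)c1cc(N2C(=O)C3=C(CCCC3)C2=O)ccc1Cl`) has butyl in place of isopropyl on an oxygen next to a carbonyl group.

With a 12-fold lower number from compound 2 to compound 3 (1.07 log units; beyond the scatter) as the closest guide, a moderate rise in this assay is expected, smaller than that step. The expected change is a 2.7-fold higher number from compound 3 to compound 4 (0.44 log units; beyond the scatter).

For compound 4 the estimated value is 500 nM, within an expected range of 120 nM to 2200 nM.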

Compound 4, half-maximal inhibitory concentration: 7760 nM
Beside the measured number, compound 4's estimate is 16-fold (1.19 log units) below it, and the stated range ends below it.
By their numbers in this assay, from the lowest: compound 3; then compound 2; then compound 4. At a limit, above all of these: compound 1.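

Lengthening the group on this oxygen does not steadily lower the number: butyl in place of isopropyl goes the other way, with a 43-fold higher number from compound 3 to compound 4 (1.63 log units; beyond the scatter), and butyl also falls behind ethyl, with a 3.6-fold higher number from compound 2 to compound 4 (0.56 log units; beyond the scatter). Butyl still retains a clear gain over hydrogen on this oxygen, with an at least 12-fold lower number from compound 1 to compound 4 (1.11 log units; beyond the scatter). That gain is open-ended since compound 1 gives only a limit: the limit of > 100000 nM in this assay, at which 1 of the 4 values shown sits.

From the compounds shown here alone, how propyl, tert-butyl or a longer chain would read on this oxygen remains open. The compounds shown therefore cannot separate the effect of branching from that of chain length.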